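Swapping an ester for a chlorophenyl ring on a shared core

The source may hold more compounds than are shown below. What is called first, only, known or untested is meant among the compounds shown, and "the series" means these compounds.

Compound 1 `CC(C)(C)OC(=O)CN(Cc1ccc2ccccc2c1)Cc1ccc([N+](=O)[O-])s1` carries a tert-butoxycarbonyl group on a saturated chain carbon bound to an amine nitrogen. In a functional assay on HEK293 cells for agonist activity at nuclear receptor subfamily 1 group D member 1 (Homo sapiens), read by a luciferase reporter, with a stated time of 24 h (on this read-out lower numbers stand for an effect already at smaller amounts and higher numbers for an effect only at larger amounts of compound), compound 1 gives "not determined" (no result reported), so no number places it on the scale. Within the data shown here, the only measured neighbour is compound 2 `CC(C)(C)OC(=O)CN(Cc1ccc([N+](=O)[O-])s1)S(=O)(=O)c1cccc2ccccc12`, which in this assay gives 800 nM; it shares much of the core but differs from compound 1 in more than one place, so its value is a reference point rather than a direct comparison.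

Compound 3 `O=[N+]([O-])c1ccc(CN(Cc2ccc(Cl)cc2)Cc2ccc3ccccc3c2)s1` is the untested analogue. It differs from compound 1 by 4-chlorophenyl in place of tert-butoxycarbonyl on a saturated chain carbon bound to an amine nitrogen. Among the measured compounds shown here, no measured pair shows this exact change, and compound 1 itself has no number, so the size and direction of the step cannot be read from the data; a step well beyond the scatter in either direction remains possible.

On the reference point of compound 2, compound 3 is expected to give about 1500 nM, with a range from 300 nM to 8000 nM.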

Compound 3, half-maximal effective concentration: 8800 nM
The estimate for compound 3 lay 5.9-fold (0.77 log units) below the measured number; measured number above the stated range.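

No step can be read from this result: compound 3 differs from compound 1 in one place, but in this assay compound 1 gives "not determined" (no result reported), and compound 2 differs from compound 3 in more than one place. The compounds shown leave open how far, and in which direction, replacing tert-butoxycarbonyl with 4-chlorophenyl moves the read-out. No measured evidence here bears on the result.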